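Urea terminus variations in the benzazepine amide series

A few compounds are considered here, and "the series" means these few. Any claim that something is new, unique, unknown or untested is made for them only; others in the source may bear on it.

Going by the values given here, compound 2 `Cc1cc(C(=O)N2CCCCc3ccccc32)ccc1CNC(=O)Nc1ccccc1F` sits second highest of the three numbers so far in a functional assay on HEK293 cells for agonist activity at Vasopressin V2 receptor (Homo sapiens), read by a luciferase reporter and cAMP accumulation; on this read-out higher numbers stand for an effect only at larger amounts of compound and lower numbers for an effect already at smaller amounts: it gives 30 nM, against 2.1 nM for compound 1 `Cc1cc(C(=O)N2CCCCc3ccccc32)ccc1CNC(=O)Nc1c(F)cccc1F` and 150 nM for compound 3 `Cc1cc(C(=O)N2CCCCc3ccccc32)ccc1CNC(=O)NCC(=O)N1CCCCC1`. Compound 4 `Cc1cc(C(=O)N2CCCCc3ccccc32)ccc1CNC(=O)N1CCC[C@H]1C(=O)OC(C)C` is the next case to be measured; it differs from compound 2 as follows: 2-(isopropoxycarbonyl)pyrrolidin-1-yl in place of (2-fluorophenyl)amino on a carbonyl carbon. The 2-fluorophenyl group is lost altogether, and with it the hydrogen-bond donor of the urea-type nitrogen.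

Among the compounds with values here, two steps bear on this. Removing a single fluoro gave a 14-fold higher number from compound 1 to compound 2 (1.15 log units; beyond the scatter), a large loss. Swapping the 2-fluorophenyl for a non-aromatic ((piperidin-1-yl)carbonyl)methyl gave a 5.0-fold higher number from compound 2 to compound 3 (0.70 log units; beyond the scatter), a modest loss. The change into compound 4 goes further than either, removing the aromatic ring and the donor together, so in this assay a loss at least in the range of those steps is expected, with no support for a gain.

For compound 4 the expected value in this assay is 250 nM, within 60 nM to 1200 nM, which corresponds to an expected step of an 8.3-fold higher number from compound 2 to compound 4 (0.92 log units; beyond the scatter).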

Compound 4, half-maximal effective concentration: 950 nM
The estimate for compound 4 lay 3.8-fold (0.58 log units) below the measured number; measured number inside the range.
By their numbers in this assay, from the lowest: compound 1; then compound 2; then compound 3; then compound 4.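

In this assay, placing 2-(isopropoxycarbonyl)pyrrolidin-1-yl on the carbonyl carbon gives the largest loss yet from the (2-fluorophenyl)amino compound (a 32-fold higher number from compound 2 to compound 4 (1.50 log units; beyond the scatter)), and the span from the (2,6-difluorophenyl)amino compound now reaches its widest (a 450-fold higher number from compound 1 to compound 4 (2.66 log units; beyond the scatter)). The lack of an aromatic ring does not settle the number at this position, since two termini without one still separate (a 6.3-fold higher number from compound 3 to compound 4 (0.80 log units; beyond the scatter)). No measurement here accounts for these losses.

The contributions of the missing amino hydrogen, the pyrrolidine ring and the ester remain unseparated, as all three change together in compound 4. A (2-fluorophenyl)(methyl)amino group, or a carboxylic acid in place of the isopropoxycarbonyl, would address separate parts of this question.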